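The source may hold more compounds than are shown below. What is called first, only, known or untested is meant among the compounds shown, and "the series" means these compounds.

The measured compounds and their readings:

Compound 1, `CCn1cc(C(=O)O)c(=O)c2cc(F)c(N3CCN(CN4C(=O)/C(=N\NC(=S)NOC)c5cc(C)ccc54)C(C)C3)c(F)c21`, gives 156000 nM in an ADME assay on MT4 cells (Homo sapiens) for cytotoxicity, read by spectrophotometry, with a stated time of 5 days; on this read-out lower numbers stand for higher toxicity in this test and higher numbers for lower toxicity in this test.
Compound 2, `CCn1cc(C(=O)O)c(=O)c2cc(F)c(N3CCN(CN4C(=O)/C(=N\NC(=S)NOC)c5cc(F)ccc54)C(C)C3)c(F)c21`, gives 178000 nM in this assay.
Compound 3, `CCn1cc(C(=O)O)c(=O)c2cc(F)c(N3CCN(CN4C(=O)/C(=N\NC(=S)NO)c5cc(F)ccc54)CC3)cc21`, gives 208000 nM in this assay.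

Compound 2 stands second highest of the three numbers. Its nearest neighbour is compound 1, which sits within the scatter of it, and the furthest is compound 3, whose number is also within the scatter of compound 2; the three readings are therefore not separable from one another on this evidence.

The compound still to be measured is compound 4, `CCn1cc(C(=O)O)c(=O)c2cc(F)c(N3CCN(CN4C(=O)/C(=N\NC(=S)NOC)c5cc(Cl)ccc54)C(C)C3)c(F)c21`. It departs from compound 2 in one place: chloro in place of fluoro on an aromatic carbon.

Among the compounds with values here, one measured step bears on this change. Between compound 1 and compound 2, fluoro replaced methyl on the same aromatic carbon, and the result was a 1.1-fold higher number from compound 1 to compound 2 (0.06 log units; within the scatter). Within the data shown here, that step did not move the number beyond the scatter, and no other pair among the three compounds probes this position.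

On that basis compound 4 is expected to stay close to compound 2, with an estimated step of a 1.0-fold lower number from compound 2 to compound 4 (0.02 log units; within the scatter) in this assay. The estimated value for compound 4 is 170000 nM, with a range from 90000 nM to 340000 nM.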

Compound 4, half-maximal cytotoxic concentration: 180000 nM
The estimate for compound 4 lay 1.1-fold (0.02 log units) below the measured number; low and high end bracket the measured number.
By their numbers in this assay, from the lowest: compounds 1, 2, 4 and 3 (each within the scatter of the next).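

In this assay chloro in place of fluoro on this aromatic carbon gave a 1.0-fold higher number from compound 2 to compound 4 (0.00 log units; within the scatter) and so did not separate the two halogens, while chloro in place of methyl gave a 1.2-fold higher number from compound 1 to compound 4 (0.06 log units; within the scatter) as a second comparison at the same place. Together with the earlier exchange of methyl for fluoro, this puts all three groups tested here, methyl, fluoro and chloro, within the scatter of one another, where the earlier compounds had offered only a single exchange on this carbon. Within this small set, on this aromatic carbon para to a fused ring, the cytotoxicity reading therefore shows no dependence on which of these three groups is present, and nothing available accounts for that outcome.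

From the compounds shown here alone, whether a larger or quite different group on this carbon, such as an amine, a methoxy group or a nitrile, would move the number beyond the scatter remains open. Compound 3 differs from the other compounds in more than one place, so the contributions of its separate differences cannot be told apart from these data.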